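The compounds below may be only part of what the source reports. "The series", "measured", "known", "first", "only" and "open" are said of these compounds alone.

Measured in an ADME assay on microsomes from liver (Mus musculus) for metabolic stability; on this read-out lower numbers stand for slow clearance and higher numbers for fast clearance:
- Compound 1 `O=C(O)Cn1nc(Cc2nc3cc(Cl)c(OC(F)(F)F)cc3[nH]2)c2ccccc2c1=O`: < 81.7 mL/min/kg
- Compound 2 `CC(C(=O)O)c1nn(Cc2cn3cc(OCC4CC4)c(Cl)cc3n2)c2ccccc2c1=O`: 80 mL/min/kg

The reading for compound 1, < 81.7 mL/min/kg, is a limit of the assay and not a number. Going by the values given here, compound 2, at 80 mL/min/kg, therefore holds the only true number, and no rank against compound 1 can be stated in this assay.

The next compound to be read is compound 3 `CC(C)(C(=O)O)c1nn(Cc2cn3cc(OCC4CC4)c(Cl)cc3n2)c2ccccc2c1=O`. It keeps compound 2 unchanged except for one place: methyl in place of hydrogen on a saturated chain carbon bound to an aromatic carbon, a carbonyl carbon and a saturated chain carbon. In other words, methyl replaces hydrogen on a saturated chain carbon bound to an aromatic carbon, a carbonyl carbon and a saturated chain carbon, turning 1-carboxyethyl into 1-carboxy-1-methylethyl.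

Among the compounds with values here, no measured pair covers this change, so the expectation starts from compound 2 at 80 mL/min/kg and from the small size of the change. The expected step of a 1.2-fold lower number from compound 2 to compound 3 (0.07 log units; within the scatter) is modest, stays within the usual scatter of repeats and leans slightly toward slower clearance. A report as a limit alone is also possible. For compound 3 the estimate is 68 mL/min/kg, with an expected range of 35 mL/min/kg to 90 mL/min/kg.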

Compound 3, clearance: < 63.4 mL/min/kg
Compound 3: no number, only a limit (the forecaster's own chance of this, stated with the estimate: 25%); middle value at least 1.0-fold (0.03 log units) away from the limit.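

In this assay, going by these compounds alone, the change from 1-carboxyethyl to 1-carboxy-1-methylethyl gives the series its only readable step at this position: an at least 1.2-fold lower number from compound 2 to compound 3 (0.10 log units; that floor lies within the scatter). Compound 3 is reported as a limit of the assay and not a number: the limit of < 63.4 mL/min/kg in this assay, at which 1 of the 3 values shown sits.

The step is therefore a floor, and its true size could lie within the scatter or beyond it, but methyl in place of hydrogen on this saturated chain carbon gives no sign of a higher number on this read-out.

Still open, as far as these compounds go, is the actual clearance of compound 3, which a limit cannot supply, so the size of the methyl step remains unknown. Also open, from the compounds shown here alone, is how this saturated chain carbon would read with fluorine or ethyl in place of methyl, and whether the same reading would hold with a primary amide or a tetrazole in place of the carboxylic acid.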